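Replacing the phenoxy group of compound 2

The compounds below may be only part of what the source reports. "The series", "measured", "known", "first", "only" and "open" are said of these compounds alone.

Two relatives sharing one core have been measured so far. In a functional assay on PC-3 cells (Homo sapiens) for antiproliferative activity, read by MTT assay, with a stated time of 48 h (on this read-out higher numbers stand for weaker inhibition and lower numbers for stronger inhibition), compound 1 `COc1ccc(CN(C(=O)Cn2cc(COc3ccc4c(C)cc(=O)oc4c3)nn2)c2cc(OC)c(OC)c(OC)c2)cc1` gives 340 nM, while compound 2 `COc1ccc(CN(C(=O)Cn2cc(COc3ccccc3)nn2)c2cc(OC)c(OC)c(OC)c2)cc1` gives 45300 nM, the higher of the two numbers and so the weaker inhibition. The next candidate is compound 3 `COc1ccc(CN(C(=O)Cn2cc(CSc3nncs3)nn2)c2cc(OC)c(OC)c(OC)c2)cc1`. The change from compound 2 to compound 3 is (1,3,4-thiadiazol-2-yl)sulfanyl in place of phenoxy on a saturated chain carbon bound to an aromatic carbon. In words, (1,3,4-thiadiazol-2-yl)sulfanyl stands in place of phenoxy on a saturated chain carbon bound to an aromatic carbon.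

Among the compounds with values here, only one measured step bears on this change. It is a 130-fold higher number from compound 1 to compound 2 (2.12 log units; beyond the scatter), a large step beyond the scatter that swaps the group on the oxygen. It shows that the number in this assay can respond strongly to a change in this part of the molecule. However, no measured step removes that oxygen or brings in sulfur, so it offers only a loose guide. With compound 2 at 45300 nM, a moderate move towards stronger inhibition is expected, far smaller than that large step. The estimated change is a 3.0-fold lower number from compound 2 to compound 3 (0.48 log units; beyond the scatter). Compound 3 is expected at 15000 nM, within a range of 4000 nM to 60000 nM.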

Compound 3, half-maximal inhibitory concentration: 16500 nM
Compound 3: middle estimate off by 1.1-fold (0.04 log units), on the low side; the measured number falls inside the stated range.
By their numbers in this assay, from the lowest: compound 1; then compound 3; then compound 2.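

The step shows that this position accepts a change of the linking atom as well as of the ring: in this assay, moving from an oxygen link to a sulfur link, with a new ring attached, gives a 2.7-fold lower number from compound 2 to compound 3 (0.44 log units; beyond the scatter). Until now, only the group on the oxygen had varied, so it was not yet known whether the number would still move once the oxygen itself was gone. The (1,3,4-thiadiazol-2-yl)sulfanyl group gives a lower number than phenoxy, but this modest step is much smaller than the one printed as a 130-fold higher number from compound 1 to compound 2 (2.12 log units; beyond the scatter), and nothing measured here explains the change.

The compounds shown leave open how much of the step belongs to the sulfur and how much to the ring, as both change together in compound 3. A phenylsulfanyl group at this place, which keeps the ring of compound 2 and carries only the sulfur of compound 3, would separate the two contributions.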